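Isomeric alkyl groups on the double-bonded nitrogen

A few compounds are considered here, and "the series" means these few. Any claim that something is new, unique, unknown or untested is made for them only; others in the source may bear on it.

Among the measured compounds shown here, compound 2 `CCC(C)C(C)/N=C(\NC#N)Nc1ccncc1` gives 8 mg/kg in a functional assay on the whole organism (blood, strain Wistar-Okamoto) with Rattus norvegicus as the target, with a stated time of 5 days (on this read-out lower numbers stand for an effect already at smaller amounts and higher numbers for an effect only at larger amounts of compound), the lowest of the two numbers measured so far; compound 1 `CCCC/N=C(\NC#N)Nc1cccnc1` gives 20 mg/kg, a gap beyond the usual scatter. Compound 3 `CC(C)C(C)(C)/N=C(\NC#N)Nc1ccncc1` is the next candidate and differs from compound 2 only by 1,1,2-trimethylpropyl in place of 1,2-dimethylbutyl on a double-bonded nitrogen. For the measured compounds named here, no measured pair separates two groups of this kind, so the data give no direction for this change; the step is expected to stay within the scatter, no change at the digits printed from compound 2 to compound 3 (within the scatter). Compound 3 is therefore expected at about 8 mg/kg, with a range from 4 mg/kg to 20 mg/kg.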

Compound 3, minimum effective dose: 20 mg/kg
Beside the measured number, compound 3's estimate is 2.5-fold (0.40 log units) below it; low and high end bracket the measured number.
By their numbers in this assay, from the lowest: compound 2; then compounds 1 and 3 (each within the scatter of the next).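

In this assay, 1,1,2-trimethylpropyl in place of 1,2-dimethylbutyl on a double-bonded nitrogen gives a 2.5-fold higher number from compound 2 to compound 3 (0.40 log units; beyond the scatter). The two groups have the same atoms, joined differently, so this position responds to the arrangement of the alkyl group and not only to its atom count. Nothing available explains the difference between these two groups. Still open, going by these compounds, is how a straight hexyl chain or a cyclohexyl group would read out at this position, and whether any group there gives a lower number than compound 2 at 8 mg/kg.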